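The source may report more compounds than this note shows. Statements on the series, on what has been measured and on what is new or still open speak of the compounds shown alone.

In a functional assay on DU-145 cells (Homo sapiens) for inhibition, read by MTT assay, with stated times of 18 h and 4 h (a higher number here means a weaker inhibitor, a lower number a stronger inhibitor), compound 1 (`CCCCCCCCOP(=O)(O)OCCSC(=S)N1CCN(C)CC1`) gives > 100000 nM, which is a limit and not a number. Compound 2 (`CCCCCCCCOP(=O)(O)OCCSC(=S)N1CCCCCC1`) gives 59100 nM. For the measured compounds named here, the only measured step, an at least 1.6-fold lower number from compound 1 to compound 2 (0.22 log units; that floor lies within the scatter), concerns the group on the thiocarbonyl carbon and leaves the chain untouched, so it gives no measure for the present change. Compound 3 (`CCCOP(=O)(O)OCCSC(=S)N1CCN(C)CC1`) differs from compound 1 in the chain: hydrogen in place of pentyl on a saturated chain carbon, three bonds along the chain from an oxygen on an unsaturated carbon, which reads octyl to propyl. No step beyond the scatter is expected in this assay, and the estimated size is a step that the limit leaves unreadable from compound 1 to compound 3. Compound 3 is expected near 120000 nM, within 60000 nM to 300000 nM, and will probably read as a limit again.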

Compound 3, half-maximal inhibitory concentration: > 100000 nM
Compound 3: no number, only a limit; the forecaster's own chance of this, stated with the estimate: 80%; the middle value lies beyond the limit too.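

No step can be read from compound 1 to compound 3, because both values are limits and not numbers: the limit of > 100000 nM in this assay, at which 2 of the 3 values shown sit. Going by these compounds, whether going from octyl to propyl changes the number in this assay at all stays open.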